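The source may hold more compounds than are shown below. What is called first, only, known or untested is meant among the compounds shown, and "the series" means these compounds.

Compound 3 `c1ccc(C2=NN(C3=NC(c4ccccc4)CS3)C(c3ccc4ccccc4c3)C2)cc1` is the parent of this small set. Within the data shown here, in a functional assay on HeLa cells (Homo sapiens) for inhibition, read by CCK-8 assay, with a stated time of 48 h (on this read-out lower numbers stand for stronger inhibition and higher numbers for weaker inhibition), compound 3 gives 3860 nM, which places it second highest of the three numbers known: its nearest neighbour is compound 1 `Clc1ccc(C2=NN(C3=NC(c4ccccc4)CS3)C(c3ccc4ccccc4c3)C2)cc1`, which gives 7560 nM in this assay, a difference that stays within the scatter, and its furthest is compound 2 `Cc1ccc(C2=NN(C3=NC(c4ccccc4)CS3)C(c3ccc4ccccc4c3)C2)cc1C`, which gives 950 nM. The steps among these three all touch the same aromatic ring. There was an 8.0-fold lower number from compound 1 to compound 2 (0.90 log units; beyond the scatter) and a 4.1-fold higher number from compound 2 to compound 3 (0.61 log units; beyond the scatter), both beyond the scatter, whereas a 2.0-fold lower number from compound 1 to compound 3 (0.29 log units; within the scatter) stayed within it.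

Compound 4 `COc1ccc(C2=NN(C3=NC(c4ccccc4)CS3)C(c3ccc4ccccc4c3)C2)cc1` differs from compound 3 by methoxy in place of hydrogen on an aromatic carbon. Among the measured compounds shown here, no measured step introduces a methoxy group, so the bearing of the earlier steps is indirect: they show that a change on this ring can move the number by a modest amount, as with compound 2, or leave it within the scatter, as with compound 1. A modest step is therefore expected, more likely toward a lower number than a higher one, with the possibility that it stays within the scatter. Compound 4 is estimated at 2500 nM, in a range from 900 nM to 7000 nM, which would be an expected step of a 1.5-fold lower number from compound 3 to compound 4 (0.19 log units; within the scatter).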

Compound 4, half-maximal inhibitory concentration: 1860 nM
Compound 4: the middle estimate sits 1.3-fold (0.13 log units) above what was measured; measured number inside the range.
By their numbers in this assay, from the lowest: compounds 2 and 4 (each within the scatter of the next); then compounds 3 and 1 (each within the scatter of the next).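

In this assay, among these compounds, the change from phenyl to 4-methoxyphenyl shows that a single group on this ring, para to a large group, can carry the number beyond the scatter toward lower values (a 2.1-fold lower number from compound 3 to compound 4 (0.32 log units; beyond the scatter)), so the 3,4-dimethylphenyl ring of compound 2 is not the only change here to do so. The identity of that single group matters, as methoxy in place of chloro at the same place gives a step beyond the scatter (a 4.1-fold lower number from compound 1 to compound 4 (0.61 log units; beyond the scatter)), whereas the 3,4-dimethylphenyl and 4-methoxyphenyl compounds cannot be told apart (a 2.0-fold higher number from compound 2 to compound 4 (0.29 log units; within the scatter), within the scatter). Nothing measured here explains these differences.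

The compounds shown leave open how a hydroxyl group, an amine or a longer ether chain such as ethoxy would read at this place, and whether methoxy would give a similar step elsewhere on the same ring. They also leave open whether the same order would hold in cells other than HeLa.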